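The source may hold more compounds than are shown below. What is called first, only, known or untested is meant among the compounds shown, and "the series" means these compounds.

In a functional assay on CCRF-CEM cells (Homo sapiens) for inhibition (a lower number here means a stronger inhibitor, a higher number a weaker inhibitor), compound 2 (`O=C1O/C(=C\Cn2cc(I)c(=O)[nH]c2=O)C(OCc2ccccc2)=C1OCc1ccccc1`) gives 3300 nM, alongside compound 1 (`O=C1O/C(=C\Cn2cc(C(F)(F)F)c(=O)[nH]c2=O)C(OCc2ccccc2)=C1OCc1ccccc1`) at 1600 nM and compound 3 (`O=C1O/C(=C\Cn2cc(Cl)c(=O)[nH]c2=O)C(OCc2ccccc2)=C1OCc1ccccc1`) at 6000 nM. Compound 2 thus lies within the scatter of compound 3 but not of compound 1. Compound 4 (`O=C1O/C(=C\Cn2cc(F)c(=O)[nH]c2=O)C(OCc2ccccc2)=C1OCc1ccccc1`) differs from compound 2 by fluoro in place of iodo on an aromatic carbon. The measured steps that bear on this exchange the same substituent: a 2.1-fold higher number from compound 1 to compound 2 (0.31 log units; beyond the scatter), a 3.8-fold higher number from compound 1 to compound 3 (0.57 log units; beyond the scatter) and a 1.8-fold higher number from compound 2 to compound 3 (0.26 log units; within the scatter). None is more than modest, and they give no direction for fluoro, so no step beyond the scatter is expected in this assay. The expected change is a 1.1-fold lower number from compound 2 to compound 4 (0.04 log units; within the scatter). For compound 4 the estimated value is 3000 nM, with an expected range of 900 nM to 9000 nM.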

Compound 4, half-maximal inhibitory concentration: 15100 nM
Estimate against measurement, compound 4: 5.0-fold (0.70 log units) below; the measured number lies above the stated range.
By their numbers in this assay, from the lowest: compound 1; then compounds 2 and 3 (each within the scatter of the next); then compound 4.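

For the compounds shown here, the substituent on this aromatic carbon matters more than the earlier compounds showed: in this assay fluoro gives a 4.6-fold higher number from compound 2 to compound 4 (0.66 log units; beyond the scatter) and a 2.5-fold higher number from compound 3 to compound 4 (0.40 log units; beyond the scatter) as well as a 9.4-fold higher number from compound 1 to compound 4 (0.97 log units; beyond the scatter), which makes compound 4 the weakest of the four. The last of these is the widest step seen so far at this position, and all three go the same way. Nothing at hand gives a reason for this loss. The compounds shown leave open where hydrogen, methyl, nitrile or an amine on this carbon would fall in this order.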